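A few compounds are considered here, and "the series" means these few. Any claim that something is new, unique, unknown or untested is made for them only; others in the source may bear on it.

Measured compounds:
Compound 1, `O=C1/C(=C/c2ccc(F)cc2)CCc2ccccc21`, gives 15900 nM in a functional assay on P388 cells (Mus musculus) for inhibition; a higher number here means a weaker inhibitor, a lower number a stronger inhibitor.
Compound 2, `O=C1/C(=C/c2ccc(Br)cc2)CCc2ccccc21`, gives 20400 nM.
Compound 3, `Cc1ccc(/C=C2\CCc3ccccc3C2=O)cc1`, gives 17700 nM.

Compound 3 stands second highest of these three numbers, with compound 1 nearest and compound 2 furthest, and the steps of a 1.1-fold higher number from compound 1 to compound 3 (0.05 log units; within the scatter) and a 1.2-fold lower number from compound 2 to compound 3 (0.06 log units; within the scatter) both lie within the scatter. Compound 4, `CN(C)c1ccc(/C=C2\CCc3ccccc3C2=O)cc1`, differs from compound 3 by dimethylamino in place of methyl on an aromatic carbon. Both measured steps that exchange the group at this position stayed within the scatter, so no step beyond the scatter is expected here either, though the incoming group is of a kind not covered by the measured compounds. Compound 4 is therefore expected at 15000 nM, between 6000 nM and 40000 nM. This estimate means a step of a 1.2-fold lower number from compound 3 to compound 4 (0.07 log units; within the scatter), expected to stay within the scatter.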

Compound 4, half-maximal inhibitory concentration: 5300 nM
The estimate for compound 4 lay 2.8-fold (0.45 log units) above the measured number, outside the stated range (below it).
By their numbers in this assay, from the lowest: compound 4; then compounds 1, 3 and 2 (each within the scatter of the next).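

Dimethylamino on the aromatic carbon para to a large group gives the first steps beyond the scatter in this assay (a 3.3-fold lower number from compound 3 to compound 4 (0.52 log units; beyond the scatter)) and (a 3.0-fold lower number from compound 1 to compound 4 (0.48 log units; beyond the scatter)) and (a 3.8-fold lower number from compound 2 to compound 4 (0.59 log units; beyond the scatter)). This position therefore does respond to the group it carries, though fluoro, bromo and methyl could not be separated there. No measurement shown accounts for the step.

Whether the nitrogen alone suffices remains open, since neither a primary amine nor methoxy appears among these compounds. Nor do they show whether diethylamino or a morpholine ring would go further.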